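Swapping a methoxymethyl chain for a hydroxymethyl chain

The compounds below may be only part of what the source reports. "The series", "measured", "known", "first", "only" and "open" are said of these compounds alone.

- compound 1 `COc1cc(C(c2ccc(O)c(OC)c2)[C@@H](C)[C@@H](C)CO)ccc1O` gives > 100000 nM (a limit of the assay)
- compound 2 `COC[C@H](C)[C@@H](C)C(c1ccc(O)c(OC)c1)c1ccc(O)c(OC)c1` gives 68000 nM (a measured number)

Among the measured compounds shown here, in a functional assay on HL-60 cells (Homo sapiens) for cytotoxicity, read by WST assay, with a stated time of 48 h (a higher number here means a weaker inhibitor, a lower number a stronger inhibitor), compound 2 gives 68000 nM as the only true number so far. The result of compound 1 is a limit of the assay. The next compound is compound 3 `COc1cc(C(c2ccc(O)c(OC)c2)[C@@H](CO)C(C)C)ccc1O`, and the change from compound 2 is 1-(hydroxymethyl)-2-methylpropyl in place of 2-(methoxymethyl)-1-methylpropyl on a saturated chain carbon bound to two aromatic carbons (the end of the chain again carries a free hydroxymethyl, as in compound 1). For the measured compounds named here, one measured step bears on this: an at least 1.4-fold lower number from compound 1 to compound 2 (0.16 log units; that floor lies within the scatter) (it links a hydroxymethyl chain and a methoxymethyl chain). That step is only a weak guide, since its floor lies within the scatter and the chain also changes shape here. A small move toward a higher number in this assay is expected, or none beyond the scatter. The expected step is a 1.3-fold higher number from compound 2 to compound 3 (0.10 log units; within the scatter) in size. For compound 3 the estimated value is 85000 nM, with an expected range from 40000 nM to 180000 nM, and the assay may report only a limit.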

Compound 3, half-maximal inhibitory concentration: > 100000 nM
Compound 3: only a limit was reported; the forecaster's own chance of this, stated with the estimate: 45%; at least 1.1-fold (0.07 log units) between middle value and limit.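

In this assay, replacing the 2-(methoxymethyl)-1-methylpropyl chain with the 1-(hydroxymethyl)-2-methylpropyl chain gives an at least 1.4-fold higher number from compound 2 to compound 3 (0.16 log units; that floor lies within the scatter), so this change cannot be called a real loss. Compound 3 joins compound 1 in giving only a limit of the assay, which means that neither chain with a free hydroxymethyl end has yielded a true number, while the step linking those two compounds cannot be read. The results shown therefore crowd at the top of what the assay reports: the limit of > 100000 nM in this assay, at which 2 of the 3 values shown sit.

This step alters both the chain end and the chain's arrangement at once, so the compounds shown do not separate the two changes. They also leave open what an amine or a carboxylic acid at the chain end, or a longer chain, would do at this position.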